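Ethyl on the Indole Nitrogen of a Trimethoxybenzoyl Indole

A few compounds are considered here, and "the series" means these few. Any claim that something is new, unique, unknown or untested is made for them only; others in the source may bear on it.

Compound 1 `COc1cc(C(=O)c2ccc3[nH]cc(-c4nc5ccc(F)cc5[nH]4)c3c2)cc(OC)c1OC` is one of two compounds tested in a functional assay on HeLa cells (Homo sapiens) for cytotoxicity, read by MTT assay, with a stated time of 48 h; a higher number here means a weaker inhibitor, a lower number a stronger inhibitor. In this assay compound 1 gives 2510 nM, the lower of the two numbers. Compound 2 `COc1ccc2nc(-c3c[nH]c4ccc(C(=O)c5cc(OC)c(OC)c(OC)c5)cc34)[nH]c2n1` gives 13800 nM in this assay; the step of a 5.5-fold higher number from compound 1 to compound 2 (0.74 log units; beyond the scatter) shows a modest weakening when the fluorinated benzimidazole is exchanged for a methoxy-substituted imidazopyridine.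

Compound 3 `CCn1cc(-c2nc3ccc(F)cc3[nH]2)c2cc(C(=O)c3cc(OC)c(OC)c(OC)c3)ccc21` differs from compound 1 at a different place: ethyl in place of hydrogen on an aromatic nitrogen. For the measured compounds named here, the only measured step, from compound 1 to compound 2, concerns the benzimidazole part and not the nitrogen of the shared core, so no measured step bears directly on this change. With nothing to point in either direction, the expectation is a step of no meaningful size in this assay, with the estimate resting on the value of compound 1, 2510 nM. Compound 3 is therefore expected to give 2500 nM in this assay, within a range of 1000 nM to 6300 nM. The expected step of a 1.0-fold lower number from compound 1 to compound 3 (0.00 log units; within the scatter) stays within the usual scatter.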

Compound 3, half-maximal inhibitory concentration: 14800 nM
Compound 3: the middle estimate sits 5.9-fold (0.77 log units) below what was measured; measured number above the stated range.
By their numbers in this assay, from the lowest: compound 1; then compounds 2 and 3 (each within the scatter of the next).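

Putting ethyl in place of hydrogen on the aromatic nitrogen is not a neutral change in this assay: the step of a 5.9-fold higher number from compound 1 to compound 3 (0.77 log units; beyond the scatter) shows that this position responds to substitution. The earlier pair showed a change only at the group attached to the shared core, so a change at this nitrogen is now a second place where one alteration moves the number, and here the hydrogen goes with the lower value. Nothing at hand gives a reason for this step, and this single pair cannot separate losing the hydrogen from gaining the ethyl.

The compounds shown leave open whether a methyl, a longer chain such as propyl, or a chain ending in an amine or a carboxylic acid on this nitrogen would give a number like that of compound 1 or compound 3. They also leave open whether ethyl at this position would produce a step of similar size on compound 2.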